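From a methylsulfonyl to a 4-methylphenylsulfonyl group

A few compounds are considered here, and "the series" means these few. Any claim that something is new, unique, unknown or untested is made for them only; others in the source may bear on it.

Measured compounds in a functional assay on NCI-H1975 cells (Homo sapiens) for inhibition, read by sulforhodamine B assay, tested at 10 uM; on this read-out higher numbers stand for more inhibition at the one concentration tested (going by the name of the read-out) and lower numbers for less inhibition:
compound 1, `Cc1ccc(S(=O)(=O)N2N=C(c3ccc(N4CCN(C)CC4)cc3)CC2c2ccc(N(C)C)cc2)cc1`, 38.1%
compound 2, `CN(C)c1ccc(C2CC(c3ccc(-n4ccnc4)cc3)=NN2C(=O)c2cc(Cl)cc(Cl)c2)cc1`, 58.7%
compound 3, `CN(C)c1ccc(C2CC(c3ccc(-n4ccnc4)cc3)=NN2S(C)(=O)=O)cc1`, -3.8%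

Compound 3 stands lowest of the three numbers: compound 1 lies above it beyond the scatter, and compound 2 lies further above. The unmeasured compound 4, `Cc1ccc(S(=O)(=O)N2N=C(c3ccc(-n4ccnc4)cc3)CC2c2ccc(N(C)C)cc2)cc1`, differs from compound 3 in one place: 4-methylphenyl in place of methyl on a sulfonyl sulfur.

Among the measured compounds shown here, one measured step bears on this. Replacing (3,5-dichlorophenyl)carbonyl on the ring nitrogen by methylsulfonyl gave a number 62.5 percentage points lower from compound 2 to compound 3 (beyond the scatter), so a small group on that nitrogen went with far less inhibition than a group carrying an aromatic ring. Compound 1, which carries the same (4-methylphenyl)sulfonyl group as compound 4 but a different group at the other end, gives a middling value. Taken together, adding an aromatic ring to the sulfonyl sulfur is expected to raise inhibition, with the step estimated at a number 38.8 percentage points higher from compound 3 to compound 4 (beyond the scatter). Compound 4 is therefore estimated at 35%, within a range from 10% to 60%.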

Compound 4, a percentage reported as inhibition, at one concentration (the size of the read-out at that concentration, not a potency): 50.5%
Compound 4: middle estimate off by 15.5 percentage points, on the low side; the range from low to high includes it.
By their numbers in this assay, from the lowest: compound 3; then compound 1; then compounds 4 and 2 (each within the scatter of the next).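

In this assay, the sulfonyl sulfur proves sensitive on its own: 4-methylphenyl in place of methyl gives a number 54.3 percentage points higher from compound 3 to compound 4 (beyond the scatter) and shows that a sulfonyl link on the ring nitrogen need not go with a low number. The sulfonyl and carbonyl links can both carry an aromatic ring here, since the change between the two groups gives a number 8.2 percentage points lower from compound 2 to compound 4 (within the scatter) and so no real difference. With (4-methylphenyl)sulfonyl held fixed, 1H-imidazol-1-yl in place of 4-methylpiperazin-1-yl on an aromatic carbon gives a number 12.4 percentage points higher from compound 1 to compound 4 (beyond the scatter) and shows that this other group counts too, though modestly.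

Nothing available explains the step at the sulfur. On these data alone, it also remains open whether a butyl chain on the sulfonyl sulfur would serve as well as 4-methylphenyl, which would separate the aromatic ring from mere size.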